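Cyclohexyl replaces a nitrogen-rich chain on the sulfonylurea

This account rests on a few compounds, and the source may have more. Where it says the series, first, only, none or still open, it means among the compounds named here.

Measured so far:
compound 1, `CCNC(=O)NS(=O)(=O)c1ccc(-n2nc(C)cc2C)cc1`, < 1%
compound 2, `Cc1cc(C)n(-c2ccc(S(=O)(=O)NC(=O)NNC(=N)N)cc2)n1`, 3%

In a functional assay on the whole organism (blood, strain albino) with Mus musculus as the target, with stated times of 6 days and 4 h, at a dose of 0.4 mmol/kg by the oral route (on this read-out higher numbers stand for more inhibition at the one dose given (going by the name of the read-out) and lower numbers for less inhibition), compound 1 sits at a limit of the assay, not at a number, as the limit of < 1% in this assay, at which 1 of the 2 values shown sits, records. Among the compounds with values here, compound 2 gives the only real number in this assay, and that number is small. Within the data shown here, the one measured step is a number at least 2 percentage points higher from compound 1 to compound 2 (that floor lies within the scatter), which lies within the usual scatter of this kind of measurement.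

Compound 3 is `Cc1cc(C)n(-c2ccc(S(=O)(=O)NC(=O)NC3CCCCC3)cc2)n1`. It differs from compound 2 by a group of 6 heavy atoms (6 carbon; one six-membered non-aromatic ring of carbon only) in place of a group of 4 heavy atoms (1 carbon, 3 nitrogen; no ring), on an amide-type nitrogen.

Among the measured compounds shown here, no measured step involves a ring entering at this position, so only the general level of the two known values can guide an expectation. Both sit low, and the step between them stays inside the scatter. For compound 3 the estimated change is therefore a number 3 percentage points higher from compound 2 to compound 3 (within the scatter), that is, none that would stand out. Compound 3 is expected to give about 6% in this assay, with a range from 0% to 25%.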

Compound 3, a percentage reported as inhibition, in the whole organism at one dose (the size of the read-out at that dose, not a potency): 10%
Estimate against measurement, compound 3: 4 percentage points below, within the range that was stated.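

Cyclohexyl is the only ring shown on this amide-type nitrogen, and in this assay the step is a number 7 percentage points higher from compound 2 to compound 3 (within the scatter), so a group with 0 hydrogen-bond donors cannot be told apart from a chain with 3 hydrogen-bond donors. Replacing ethyl with cyclohexyl gives a number at least 9 percentage points higher from compound 1 to compound 3 (that floor lies within the scatter), so this comparison also fails to separate the two groups. Compound 1 stands at a limit, not at a number: the limit of < 1% in this assay, at which 1 of the 3 values shown sits.

From the compounds shown here alone, it remains open whether any group at this position can move the read-out clearly beyond the scatter. A phenyl ring, a longer chain such as n-butyl, or a chain ending in a carboxylic acid would each test this on the same core.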